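Moving a methoxy group on a benzyl ether of an adrenergic ligand

The source may hold more compounds than are shown below. What is called first, only, known or untested is meant among the compounds shown, and "the series" means these compounds.

Measured compounds:
Compound 1, `COc1cccc(OC)c1OCCNCCOc1ccccc1OCc1ccccc1`: 0.468 nM
Compound 2, `COc1cccc(OC)c1OCCNCCOc1ccccc1OCc1ccccc1[N+](=O)[O-]`: 7.94 nM
Compound 3, `COc1ccccc1COc1ccccc1OCCNCCOc1c(OC)cccc1OC`: 2 nM

In an assay on CHO cells for displacement of a labelled ligand from Alpha-1A adrenergic receptor (Homo sapiens) (on this read-out higher numbers stand for weaker inhibition and lower numbers for stronger inhibition), compound 3 gives the second highest of the three numbers. It stands apart from both neighbours: the step of a 4.3-fold higher number from compound 1 to compound 3 (0.63 log units; beyond the scatter) shows that adding a methoxy group raised the number, while a 4.0-fold lower number from compound 2 to compound 3 (0.60 log units; beyond the scatter) shows that the nitro-bearing compound sits higher still, and a 17-fold higher number from compound 1 to compound 2 (1.23 log units; beyond the scatter) was the largest step of the set.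

Compound 4, `COc1ccc(COc2ccccc2OCCNCCOc2c(OC)cccc2OC)cc1`, keeps every atom of compound 3 but joins them differently: 4-methoxyphenyl in place of 2-methoxyphenyl on a saturated chain carbon bound to an oxygen on an aromatic ring. Among the compounds with values here, no measured pair shows a methoxy group moved from one ring carbon to another, so the only guidance is indirect. The step of a 4.3-fold higher number from compound 1 to compound 3 (0.63 log units; beyond the scatter) shows that a methoxy group on this ring can shift the number modestly, and a 4.0-fold lower number from compound 2 to compound 3 (0.60 log units; beyond the scatter) shows that what sits on this ring matters. A positional move of the same group is expected to change the number by less than either of those steps, with no clear direction.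

Compound 4 is therefore expected at 1.5 nM, within a range of 0.4 nM to 6 nM, which means an expected step of a 1.3-fold lower number from compound 3 to compound 4 (0.12 log units; within the scatter).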

Compound 4, inhibition constant: 2 nM
Compound 4: the middle estimate sits 1.3-fold (0.12 log units) below what was measured, and the stated range covers the measured number.
By their numbers in this assay, from the lowest: compound 1; then compounds 3 and 4 (each within the scatter of the next); then compound 2.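

In this assay, within the data shown here, replacing 2-methoxyphenyl with 4-methoxyphenyl on the saturated chain carbon bound to an oxygen on an aromatic ring gives no change at the digits printed from compound 3 to compound 4 (within the scatter) within this series, the first direct look at moving the methoxy group around this ring. Placed in either way, the methoxy-bearing compound keeps its standing against the other two compounds: there is a 4.3-fold higher number from compound 1 to compound 4 (0.63 log units; beyond the scatter) on adding the group, and a 4.0-fold lower number from compound 2 to compound 4 (0.60 log units; beyond the scatter) on exchanging 2-nitrophenyl for 4-methoxyphenyl. Nothing available here accounts for why the two placements read alike.

On these data alone, whether the nitro group would give the same result after a similar move remains open. So does the effect on the number of an amine or a carboxylic acid on this ring.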